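This account rests on a few compounds, and the source may have more. Where it says the series, first, only, none or still open, it means among the compounds named here.

In a functional assay on MCF7 cells (Homo sapiens) for inhibition, read by MTT assay, with a stated time of 48 h (a lower number here means a stronger inhibitor, a higher number a weaker inhibitor), the measured compounds read:
- compound 1 `c1ccc(-c2ccnc3c2c(-c2ccccc2)nn3-c2ccccc2)cc1` gives 28200 nM 
- compound 2 `Clc1ccc(-c2ccnc3c2c(-c2ccccc2)nn3-c2ccccc2)cc1` gives 61100 nM 
- compound 3 `COc1ccc(-c2ccnc3c2c(-c2ccccc2)nn3-c2ccccc2)cc1` gives 28700 nM 

The methoxy member sits in the lower pair of the three numbers (a 1.0-fold higher number from compound 1 to compound 3 (0.01 log units; within the scatter) and a 2.1-fold lower number from compound 2 to compound 3 (0.33 log units; beyond the scatter)) and is level with the unsubstituted member. The next compound, compound 4 `Fc1ccc(-c2ccnc3c2c(-c2ccccc2)nn3-c2ccccc2)cc1`, has fluoro in place of methoxy on an aromatic carbon, para to a large group (fluoro in place of methoxy on an aromatic carbon). Among the measured compounds shown here, no fluoro member has been measured, so the nearest guides are the other changes at this place. Methoxy for hydrogen moved nothing (a 1.0-fold higher number from compound 1 to compound 3 (0.01 log units; within the scatter)), while chloro for hydrogen gave a modest step (a 2.2-fold higher number from compound 1 to compound 2 (0.34 log units; beyond the scatter)). Three compounds make a thin base, and the chloro member is the only one that departs from a flat picture. Fluoro is therefore expected to fall within the span of these numbers. The expected change in this assay is a 1.3-fold higher number from compound 3 to compound 4 (0.10 log units; within the scatter), a slightly higher number that stays inside the scatter. For compound 4 the estimated value is 36000 nM, with an expected range from 20000 nM to 65000 nM.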

Compound 4, half-maximal inhibitory concentration: 1570 nM
Beside the measured number, compound 4's estimate is 23-fold (1.36 log units) above it; the measured number lies below the stated range.
By their numbers in this assay, from the lowest: compound 4; then compounds 1 and 3 (each within the scatter of the next); then compound 2.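

At the position on the six-membered aromatic ring of carbon only, para to a large group, the series is no longer flat in this assay: fluoro stands well apart, with an 18-fold lower number from compound 1 to compound 4 (1.25 log units; beyond the scatter), an 18-fold lower number from compound 3 to compound 4 (1.26 log units; beyond the scatter) and a 39-fold lower number from compound 2 to compound 4 (1.59 log units; beyond the scatter). The two halogens also pull in opposite directions against hydrogen, as chloro gives a 2.2-fold higher number from compound 1 to compound 2 (0.34 log units; beyond the scatter), so the response at this place does not follow a shared halogen trend across these compounds. Nothing available accounts for the size of the fluoro step.

On these data alone, whether the gain is specific to fluoro remains open, and how bromo, a nitrile, an amine or a carboxylic acid at this place would read in this assay is unknown. Also unresolved is whether fluoro elsewhere on the shared core would give a comparable step.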